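Replacing a tert-butyl group with an oxolane on a pyrimidinone

The source may hold more compounds than are shown below. What is called first, only, known or untested is meant among the compounds shown, and "the series" means these compounds.

Compound 1, `CC(C)(C)COc1ccc(-c2cc(=O)[nH]c(N)n2)cc1`, was tested in a physicochemical assay for solubility, in phosphate buffer, at pH 7.4; on this read-out lower numbers stand for lower solubility and higher numbers for higher solubility. In this assay compound 1 gives 3100 nM, the lowest of the two numbers recorded here. Going by the values given here, the only other compound with a result is compound 2, `Nc1nc(-c2cccc(OC(F)(F)F)c2)cc(=O)[nH]1`, which gives 330000 nM; the two values lie far apart, well beyond the usual scatter. Compound 3, `Nc1nc(-c2ccc(OCC3CCOC3)cc2)cc(=O)[nH]1`, has not yet been measured. It differs from compound 1 in one place only: oxolan-3-yl in place of tert-butyl on a saturated chain carbon bound to an oxygen on an aromatic ring. The group that leaves carries no hydrogen-bond acceptor, while the group that enters brings one five-membered non-aromatic ring with 1 hetero atom and 1 hydrogen-bond acceptor. Among the compounds with values here, no measured pair shows this exact change, so the expected step rests on the structures alone. For compound 3 the step of an 8.1-fold higher number from compound 1 to compound 3 (0.91 log units; beyond the scatter) is expected to go toward higher solubility, beyond the scatter. Compound 3 is therefore estimated at 25000 nM, within a range from 5000 nM to 120000 nM.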

Compound 3, solubility: 58000 nM
The estimate for compound 3 lay 2.3-fold (0.37 log units) below the measured number; low and high end bracket the measured number.
By their numbers in this assay, from the lowest: compound 1; then compound 3; then compound 2.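

In this assay putting oxolan-3-yl in place of tert-butyl on a saturated chain carbon bound to an oxygen on an aromatic ring gives a 19-fold higher number from compound 1 to compound 3 (1.27 log units; beyond the scatter) and so shows that a single change at this end of the molecule can move the read-out by a large step. The core of compound 1 stays untouched in compound 3, so the step belongs to this one swap. Nothing measured here says what lies behind the step.

As far as these compounds go, the ring and its oxygen arrive together, so their shares stay unknown: cyclopentyl, an all-carbon five-membered ring, would separate them. Pyrrolidin-3-yl, which carries an amine in the ring, would show whether a different hetero atom at this place gives a step of similar size.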